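The source may hold more compounds than are shown below. What is called first, only, known or untested is meant among the compounds shown, and "the series" means these compounds.

Measured compounds:
compound 1, `COc1ccc(-c2nc(C)c(C(=O)CSc3nc(N)c(C#N)c(-c4ccccc4)n3)s2)cc1`, -2.8%
compound 2, `Cc1nc(-c2ccc(Cl)cc2)sc1C(=O)CSc1nc(N)c(C#N)c(-c2ccc(Cl)cc2)n1`, -3.7%
compound 3, `COc1ccc(-c2nc(SCC(=O)c3sc(-c4ccc(Cl)cc4)nc3C)nc(N)c2C#N)cc1`, 1.2%

All three were tested in an assay on membranes from CHO cells for displacement of a labelled ligand from adenosine receptor A1 (Homo sapiens), read by scintillation counting, with a stated time of 60 min, tested at 1 uM (on this read-out lower numbers stand for less inhibition and higher numbers for more inhibition at the one concentration tested (going by the name of the read-out)), and none of them shows a read-out that sets it apart: the gap between compound 3 and compound 1, and the gap between compound 3 and compound 2, both lie within the usual scatter of this measurement, so the three numbers are best read as one indistinguishable cluster near zero.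

Going by the values given here, the one single-point change among the measured compounds, a number 4.9 percentage points higher from compound 2 to compound 3 (within the scatter), is a methoxy in place of chloro on an aromatic carbon, and it left the read-out where it was.

Compound 4, `Cc1nc(-c2ccc(Cl)cc2)sc1C(=O)CSc1nc(N)c(C#N)c(-c2ccccc2)n1`, has not yet been measured. Compared with compound 3 the difference is hydrogen in place of methoxy on an aromatic carbon. Among the compounds with values here, no measured pair shows exactly this change, so the only guide is that the one change at this same aromatic position, the step from compound 2 to compound 3, stayed within the scatter, and that all three measured values sit close to zero. The expected step is therefore a number 2.2 percentage points lower from compound 3 to compound 4 (within the scatter), meaning no change beyond the scatter in this assay.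

Compound 4 is thus estimated at -1%, with a range from -10% to 8%.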

Compound 4, a percentage reported as inhibition, at one concentration (the size of the read-out at that concentration, not a potency): 8.7%
The estimate for compound 4 lay 9.7 percentage points below the measured number; the whole stated range lies below it.
By their numbers in this assay, from the lowest: compounds 2, 1, 3 and 4 (each within the scatter of the next, the first and the last beyond it).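

In this assay, hydrogen in place of methoxy on this aromatic carbon, para to a large group, gives a number 7.5 percentage points higher from compound 3 to compound 4 (within the scatter), whereas hydrogen in place of chloro at the same place gives a number 12.4 percentage points higher from compound 2 to compound 4 (beyond the scatter), so this position, which had looked silent, now shows a modest difference between two of its groups. A step of similar size appears when the swap is made on the other aromatic ring, where chloro in place of methoxy gives a number 11.5 percentage points higher from compound 1 to compound 4 (beyond the scatter), so the phenyl compound 4 separates from both compound 1 and compound 2, though not from compound 3. Exchanging chloro and methoxy therefore does not have one fixed outcome on this read-out, and the answer depends on the compound that carries the change: the same change on two cores in this assay, a number 4.9 percentage points higher (within the scatter) from compound 2 to compound 3 and a number 11.5 percentage points lower (beyond the scatter) from compound 4 to compound 1, 16.4 percentage points apart, beyond the scatter of two such steps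

Even compound 4 stands at only 8.7% at the one concentration tested, so these numbers give no potency and show only small differences close to zero. From the compounds shown here alone, whether an amine, a carboxylic acid or a longer alkoxy chain on this aromatic carbon would move the read-out further remains open.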